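A few compounds are considered here, and "the series" means these few. Any claim that something is new, unique, unknown or untested is made for them only; others in the source may bear on it.

Compound 1 `COc1ccc(/C=C\C(=O)O)c(OCc2cn(-c3ccccc3I)nn2)c1CC=C(C)C` anchors this series, yet for compound 1 the result in a functional assay on COLO 205 cells (Homo sapiens) for cytotoxicity, read by MTT assay, with a stated time of 24 h (a higher number here means a weaker inhibitor, a lower number a stronger inhibitor), is "not determined" (no result reported); no number stands against it. Compound 2 `COc1ccc(-n2cc(COc3c(/C=C\C(=O)O)ccc(OC)c3CC=C(C)C)nn2)cc1` is in the same position, its entry in this assay being "not determined" (no result reported). The only reported figure comes from compound 3 `COc1ccc(/C=C\C(=O)O)c(OCc2cn(-c3cccc(C#N)c3)nn2)c1CC=C(C)C`, which in this assay gives 26800 nM. Compound 4 `COc1ccc(/C=C\C(=O)O)c(OCc2cn(-c3ccc(C#N)cc3)nn2)c1CC=C(C)C` differs from compound 1 by 4-cyanophenyl in place of 2-iodophenyl on an aromatic nitrogen. Going by the values given here, with no value for compound 1, no step can be computed for this change, and no direction can be assigned beyond the scatter. Compound 4 is expected to land near the reading of compound 3, which also bears a cyanophenyl group on that aromatic nitrogen, so an estimate of 25000 nM with a range of 8000 nM to 80000 nM is given.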

Compound 4, half-maximal inhibitory concentration: 32000 nM
Estimate against measurement, compound 4: 1.3-fold (0.11 log units) below; low and high end bracket the measured number.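

In this assay, 4-cyanophenyl in place of 3-cyanophenyl on the aromatic nitrogen gives a 1.2-fold higher number from compound 3 to compound 4 (0.08 log units; within the scatter), so the two cyanophenyl compounds cannot be told apart here. Steps involving compound 1 or compound 2 cannot be read, which leaves the comparison with 2-iodophenyl unresolved. No supporting data bear on this result.

Open, on these data alone, is whether any other group on that aromatic nitrogen, such as an aminophenyl or a carboxyphenyl, would shift the number beyond the scatter. Also open, as far as these compounds go, is whether an unsubstituted phenyl would read alike.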